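Removing one methoxy from the aryl ring of compound 2

A few compounds are considered here, and "the series" means these few. Any claim that something is new, unique, unknown or untested is made for them only; others in the source may bear on it.

Measured so far:
compound 1 `COc1ccc(-c2cc(/C=C/C(=O)c3ccc(N)cc3)[nH]n2)cc1` — 11600 nM
compound 2 `COc1cc(-c2cc(/C=C/C(=O)c3ccc(N)cc3)[nH]n2)cc(OC)c1OC` — 9980 nM

Both compounds share the same core and differ only in the methoxy pattern on the aryl ring. In a functional assay on SNB-19 cells (Homo sapiens) for inhibition, read by sulforhodamine B assay, with a stated time of 48 h (a higher number here means a weaker inhibitor of growth, a lower number a stronger inhibitor of growth), compound 1 gives 11600 nM and compound 2 gives 9980 nM. Compound 2 holds the smaller of the two numbers, but the gap to compound 1 lies within the scatter, so the two cannot be told apart on the numbers shown.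

The next compound, compound 3 `COc1ccc(-c2cc(/C=C/C(=O)c3ccc(N)cc3)[nH]n2)cc1OC`, is derived from compound 2 by the change (hydrogen in place of methoxy on an aromatic carbon), that is, hydrogen in place of methoxy on an aromatic carbon, the site being ortho to a methoxy group and meta to a methoxy group and to a large group. For the measured compounds named here, no step between measured compounds is available for this change. Since compound 1 and compound 2 bracket compound 3 in methoxy count and lie within the scatter of each other, no step beyond the scatter is expected in this assay in either direction.

Compound 3 is therefore estimated at 10500 nM, with a range of 5000 nM to 22000 nM, which corresponds to an expected step of a 1.1-fold higher number from compound 2 to compound 3 (0.02 log units; within the scatter).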

Compound 3, concentration for total growth inhibition: 18000 nM
Compound 3: middle estimate off by 1.7-fold (0.23 log units), on the low side, within the range that was stated.
By their numbers in this assay, from the lowest: compounds 2, 1 and 3 (each within the scatter of the next).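

In this assay, the change at the site ortho to a methoxy group and meta to a large group, hydrogen in place of methoxy on an aromatic carbon, gives a 1.8-fold higher number from compound 2 to compound 3 (0.26 log units; within the scatter) and the reverse kind of change, methoxy in place of hydrogen on an aromatic carbon, gives a 1.6-fold higher number from compound 1 to compound 3 (0.19 log units; within the scatter) on the shared core. For the compounds shown here, these are the first single-place comparisons, which compound 1 and compound 2 could not supply as they differ in two places, and both steps lie within the scatter, so neither methoxy shows a readable contribution to the number in this set. Nothing available bears on why the numbers fall as they do.

As far as these compounds go, whether a group other than methoxy at this site, such as a hydroxyl, a fluorine or an amine, would give a step beyond the scatter stays open. Also open, from the compounds shown here alone, is whether a change elsewhere on the shared core, such as an acetyl group on its amine, would separate compounds in a way these methoxy changes do not.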